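Removing the Ring Fluorine from a Lymphocyte Inhibitor

This account rests on a few compounds, and the source may have more. Where it says the series, first, only, none or still open, it means among the compounds named here.

Measured compounds:
compound 1, `Nc1nc(N2CCN(C(=O)COc3ccc(Cl)cc3)CC2)c2cc(F)sc2n1`, gives 700 nM in a functional assay on cells (Lymphocyte); a higher number here means a weaker inhibitor, a lower number a stronger inhibitor
compound 2, `Nc1nc(N2CCN(C(=O)CCc3ccccc3)CC2)c2cc(F)sc2n1`, gives 6990 nM in this assay

Among the compounds with values here, compound 1 stands lowest of the two numbers measured so far in this assay, and compound 2 is its only neighbour, the step being a 10-fold higher number from compound 1 to compound 2 (1.00 log units; beyond the scatter). That step changes the amide side chain: benzyl in place of 4-chlorophenoxy on a saturated chain carbon bound to a carbonyl carbon.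

Compound 3, `Nc1nc(N2CCN(C(=O)COc3ccc(Cl)cc3)CC2)c2ccsc2n1`, differs from compound 1 in another place entirely: hydrogen in place of fluoro on an aromatic carbon. Within the data shown here, no measured step touches the fused ring system, so the side-chain step from compound 1 to compound 2 says nothing directly about the size or direction of this change. Among the measured compounds shown here, with no bearing step, compound 3 is expected to show no step beyond the scatter, that is a 1.4-fold higher number from compound 1 to compound 3 (0.15 log units; within the scatter). The estimate for compound 3 in this assay is therefore 1000 nM, with a range from 300 nM to 3500 nM.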

Compound 3, half-maximal inhibitory concentration: 330 nM
Estimate against measurement, compound 3: 3.0-fold (0.48 log units) above; low and high end bracket the measured number.
By their numbers in this assay, from the lowest: compound 3; then compound 1; then compound 2.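

In this assay, the fluoro on an aromatic carbon next to the ring sulfur proves not to be required for inhibition: hydrogen in its place gives a 2.1-fold lower number from compound 1 to compound 3 (0.33 log units; beyond the scatter) on the 4-chlorophenoxy side chain. Within the data shown here, this is the first step measured on the fused ring system, and it shows that this position also moves the number, though the side-chain change gives the larger step, a 10-fold higher number from compound 1 to compound 2 (1.00 log units; beyond the scatter) in the opposite direction for that pair. No measured information accounts for the lower number with hydrogen.

Among these compounds, the fluoro-to-hydrogen change is seen only with the 4-chlorophenoxy side chain, so whether it holds with the benzyl side chain of compound 2 stays open. As far as these compounds go, how a chloro, methyl or nitrile group at this carbon would compare with hydrogen also remains open.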